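The compounds below may be only part of what the source reports. "The series", "measured", "known", "first", "only" and "open" are said of these compounds alone.

Of the compounds shown here, two have so far been measured in a physicochemical assay for solubility, read by LC-MS, in phosphate buffer, measured as kinetic solubility, with a stated time of 24 h, at 25 degrees C, at pH 7.4; a lower number here means a less soluble compound, a higher number a more soluble compound. Compound 1 `Nc1nccc(-c2cc(OC3CCOC3)c3c(N)n[nH]c3c2)n1` gives 751000 nM, the higher of the two numbers, while compound 2 `Nc1cc(-c2ccc3cn[nH]c3c2)ncn1` gives 332000 nM, a value that lies beyond the usual scatter from that of compound 1. Compound 3 `Nc1nccc(-c2cc(OC3CCCOC3)c3c(N)n[nH]c3c2)n1` has not yet been measured. It differs from compound 1 in one place: oxan-3-yl in place of oxolan-3-yl on an oxygen on an aromatic ring. Going by the values given here, with no measured pair of this kind to lean on, the expected step is small and downward, at most just beyond the scatter, estimated as a 1.5-fold lower number from compound 1 to compound 3 (0.18 log units; within the scatter). Compound 3 is accordingly expected to give about 500000 nM, within a range from 250000 nM to 900000 nM.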

Compound 3, solubility: 1000000 nM
Estimate against measurement, compound 3: 2.0-fold (0.30 log units) below, and the stated range ends below it.
By their numbers in this assay, from the lowest: compound 2; then compounds 1 and 3 (each within the scatter of the next).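

Placing oxan-3-yl in place of oxolan-3-yl on an oxygen on an aromatic ring gives the first one-place comparison in this assay, with a 1.3-fold higher number from compound 1 to compound 3 (0.12 log units; within the scatter) as its step. At this position, then, a six-membered ring can stand in for a five-membered one without a difference that can be told apart from repeat-measurement scatter. Nothing measured here gives a reason for this result. Still open, as far as these compounds go, is whether a group of another kind on this oxygen, such as a piperidine ring or a longer chain ending in an amine, would give a step beyond the scatter.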